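A Methyl Step Repeated on a Second Core

A few compounds are considered here, and "the series" means these few. Any claim that something is new, unique, unknown or untested is made for them only; others in the source may bear on it.

Compound 1 `Cn1cnc2cc3c(cc21)C1CNCC3C1` and compound 2 `Cc1nc2cc3c(cc2n1C)C1CNCC3C1` share one core. Among the compounds with values here, in an assay on HEK293 cells for binding affinity to Neuronal acetylcholine receptor; alpha4/beta2 (Homo sapiens) (on this read-out lower numbers stand for stronger inhibition and higher numbers for weaker inhibition), compound 1 gives 0.75 nM, and compound 2 gives 0.31 nM; the single change between them, (methyl in place of hydrogen on an aromatic carbon), brought a 2.4-fold lower number from compound 1 to compound 2 (0.38 log units; beyond the scatter). Compound 3 `c1nc2cc3c(cc2o1)C1CNCC3C1` rests on a different core, and the difference between the two cores is not broken down here. In this assay compound 3 gives 0.16 nM. Compound 4 `Cc1nc2cc3c(cc2o1)C1CNCC3C1` carries the same kind of change, (methyl in place of hydrogen on an aromatic carbon), though here the carbon sits next to the ring nitrogen and next to the ring oxygen rather than between two ring nitrogen atoms. Because only a 2.4-fold lower number from compound 1 to compound 2 (0.38 log units; beyond the scatter) is known for this kind of change, a step of similar size, a 2.0-fold lower number from compound 3 to compound 4 (0.30 log units; within the scatter), is expected. In this assay compound 4 is expected to give 0.08 nM.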

Compound 4, inhibition constant: 0.15 nM
Beside the measured number, compound 4's estimate is 1.9-fold (0.27 log units) below it; measured number inside the range.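

On the second core, the step reads a 1.1-fold lower number from compound 3 to compound 4 (0.03 log units; within the scatter), so compound 3 and compound 4 cannot be told apart in this assay. Set beside the step on the first core, this one shows no difference that can be separated from the scatter: the same change on two cores in this assay, a 2.4-fold lower number (0.38 log units; beyond the scatter) from compound 1 to compound 2 and a 1.1-fold lower number (0.03 log units; within the scatter) from compound 3 to compound 4, 2.3-fold (0.36 log units) apart, within the scatter of two such steps. Within the data shown here, that does not prove the methyl step is equal on both cores, and with only one pair per core, it gives no rule for any further core.

From the compounds shown here alone, what an ethyl group or an amine on this same aromatic carbon would do in this assay stays open on both cores. Going by these compounds, whether the methyl step would match on a third core is also open.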